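Imidazolylmethyl biaryls: from compound 2 to compound 3

A few compounds are considered here, and "the series" means these few. Any claim that something is new, unique, unknown or untested is made for them only; others in the source may bear on it.

Measured so far:
compound 1 `Cc1cscc1-c1ccc(Cn2ccnc2)cc1`, 27%
compound 2 `c1cn(Cc2ccc(-c3cncnc3)cc2)cn1`, 3%

Both numbers come from an assay for inhibition of steroid 17-alpha-hydroxylase/17,20 lyase (Homo sapiens), using NADPH, tested at 2 uM; a higher number here means a stronger effect of the compound at the concentration tested, a lower number a weaker effect. Compound 2 stands lowest of the two; its nearest neighbour is compound 1, and the step of a number 24 percentage points lower from compound 1 to compound 2 (beyond the scatter) lies beyond the scatter. Compound 3 `c1cncc(-c2ccc(Cn3ccnc3)cc2)c1` is not yet measured. It differs from compound 2 by pyridin-3-yl in place of pyrimidin-5-yl on an aromatic carbon. Going by the values given here, no measured step covers this exchange: the only step in hand, a number 24 percentage points lower from compound 1 to compound 2 (beyond the scatter), replaces a different group at the same place, so it gives no size for the move from pyrimidin-5-yl to pyridin-3-yl. Compound 2 gives 3%, so little room remains downward and any step beyond the scatter would have to be upward. Compound 3 is therefore expected at 15%, with a range from 0% to 45%. This estimate means an expected step of a number 12 percentage points higher from compound 2 to compound 3 (beyond the scatter), held with low confidence.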

Compound 3, a percentage reported as inhibition, at one concentration (the size of the read-out at that concentration, not a potency): 14%
Beside the measured number, compound 3's estimate is 1 percentage points above it; low and high end bracket the measured number.
By their numbers in this assay, from the lowest: compound 2; then compound 3; then compound 1.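

In this assay, going by these compounds alone, pyridin-3-yl in place of pyrimidin-5-yl on the aromatic carbon para to the (1H-imidazol-1-yl)methyl group gives a number 11 percentage points higher from compound 2 to compound 3 (beyond the scatter) and so puts a first size on this exchange between two six-membered aromatic rings, one with 1 hetero atom and the other with 2 hetero atoms. Pyridin-3-yl in place of 4-methylthiophen-3-yl at the same place gives a number 13 percentage points lower from compound 1 to compound 3 (beyond the scatter) and thus sets pyridin-3-yl apart from both other groups, in the order pyrimidin-5-yl, pyridin-3-yl, 4-methylthiophen-3-yl. Nothing in hand bears on what lies behind these steps.

Going by these compounds, what a plain phenyl ring or a pyridin-3-yl carrying an amine would give at this place remains open. On these data alone, with read-outs at a single concentration, the potency of all three compounds also remains open.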